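Removing a cyclopropyl from a weak inhibitor of the steroidogenic enzyme

The source may report more compounds than this note shows. Statements on the series, on what has been measured and on what is new or still open speak of the compounds shown alone.

Measured so far, in an ADME assay on cells for inhibition of cytochrome P450 11B1, mitochondrial (Homo sapiens), read by HTRF; on this read-out lower numbers stand for stronger inhibition and higher numbers for weaker inhibition:
- compound 1, `O=C1c2cc(F)c(Cl)cc2CCN1c1cccnc1`, gives 3540 nM
- compound 2, `CC(=O)N[C@@H]1CCCc2c1cncc2N1C(=O)c2ccc(Cl)cc2[C@@H]1C1CC1`, is reported only as a limit of > 30000 nM
- compound 3, `O=C(Nc1cccnc1)c1ccc(Cl)cc1F`, is reported only as a limit of > 3000 nM

Compound 2 is the larger of the three, with an acetamide on a saturated ring and a cyclopropyl on the five-membered ring of its fused core. In this assay compound 2 does not reach a number at all; its result sits at the limit of > 30000 nM in this assay, at which 1 of the 3 values shown sits. Compound 3 likewise sits at the limit of > 3000 nM in this assay, at which 1 of the 3 values shown sits. Only compound 1 returns a measured value.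

Compound 4, `CC(=O)N[C@@H]1CCCc2c1cncc2N1Cc2cc(Cl)ccc2C1=O`, is the next member to be examined in this assay. It differs from compound 2 in one place: hydrogen in place of cyclopropyl on a saturated ring carbon, in words, hydrogen in place of cyclopropyl on a saturated ring carbon. No measured pair shows what this change does in this assay, and no cause for the result of compound 2 is known. With compound 2 at a limit, any movement can only be towards stronger inhibition or none at all.

Compound 4 is expected to give 12000 nM, within 2000 nM to 60000 nM. The step from compound 2 to compound 4 is therefore estimated as an at least 2.5-fold lower number from compound 2 to compound 4 (0.39 log units; beyond the scatter), and a result that is again only a limit is thought about as likely as a number.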

Compound 4, half-maximal inhibitory concentration: 2330 nM
The estimate for compound 4 lay 5.2-fold (0.71 log units) above the measured number; measured number inside the range.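

In this assay, hydrogen in place of cyclopropyl on a saturated ring carbon gives an at least 12-fold lower number from compound 2 to compound 4 (1.10 log units; beyond the scatter). Among these compounds, this is the first measured sign that the group at this position, next to the ring nitrogen, has a large bearing on inhibition of this enzyme: with the cyclopropyl gone, the number falls and inhibition becomes stronger. Compound 2 is reported only as a limit, so the step gives the least that the change can amount to and not its full size: the limit of > 30000 nM in this assay, at which 1 of the 4 values shown sits.

The compounds shown carry only hydrogen or cyclopropyl at this position, so it stays open whether a methyl or a hydroxyl group there would give a number closer to that of compound 4 or would again end at a limit. They also give no cause for the step, and this one pair cannot tell whether the same change would act in the same way on another core.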